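Moving the Fluorine Around a Triazole Aryl Group

The compounds below may be only part of what the source reports. "The series", "measured", "known", "first", "only" and "open" are said of these compounds alone.

Compound 1 `O=c1[nH]cc(S(=O)(=O)Nc2cccc(-c3cn(-c4ccccc4F)nn3)c2)c(=O)[nH]1` and compound 2 `O=c1[nH]cc(S(=O)(=O)Nc2cccc(-c3cn(-c4cccc(F)c4)nn3)c2)c(=O)[nH]1` share one core, while compound 3 `O=c1[nH]cc(S(=O)(=O)Nc2ccc(-c3cn(-c4ccccc4F)nn3)cc2)c(=O)[nH]1` and compound 4 `O=c1[nH]cc(S(=O)(=O)Nc2ccc(-c3cn(-c4cccc(F)c4)nn3)cc2)c(=O)[nH]1` share another; the difference between the two cores is not broken down here. In a functional assay on A549 cells (Homo sapiens) for antiproliferative activity, read by MTT assay, with a stated time of 24 h (a lower number here means a stronger inhibitor, a higher number a weaker inhibitor), compound 1 reaches only a limit, > 20000 nM. Compound 2 gives 7200 nM in this assay, and compound 3 gives 5960 nM. The change 3-fluorophenyl in place of 2-fluorophenyl on an aromatic nitrogen produced an at least 2.7-fold lower number from compound 1 to compound 2 (0.44 log units; beyond the scatter), a step whose true size is hidden because compound 1 sits at the limit of > 20000 nM in this assay, at which 1 of the 3 values shown sits. Compound 4 carries the same change, (3-fluorophenyl in place of 2-fluorophenyl on an aromatic nitrogen), on the other core. Resting on the step of an at least 2.7-fold lower number from compound 1 to compound 2 (0.44 log units; beyond the scatter), the expected step for compound 4 is a 2.4-fold lower number from compound 3 to compound 4 (0.38 log units; beyond the scatter). Compound 4 is estimated at 2500 nM, with a likely range from 1000 nM to 6000 nM.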

Compound 4, half-maximal inhibitory concentration: 9980 nM
For compound 4 the middle estimate is 4.0-fold (0.60 log units) below the measured one; measured number outside the range, above it.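

Carrying the change to the core of compound 3 gives a 1.7-fold higher number from compound 3 to compound 4 (0.22 log units; within the scatter), so in this assay the gain seen on the core of compound 1 does not reappear, and the two steps disagree: the same change on two cores in this assay, an at least 2.7-fold lower number (0.44 log units; beyond the scatter) from compound 1 to compound 2 and a 1.7-fold higher number (0.22 log units; within the scatter) from compound 3 to compound 4, at least 4.6-fold (0.66 log units) apart, beyond the scatter of two such steps. On these data alone, compound 1 stands at a limit and not at a number, so the true size of the first step stays unknown: the limit of > 20000 nM in this assay, at which 1 of the 4 values shown sits. This pair of cores shows that the effect of the change cannot be assumed to carry from one core to the other in this series, but it does not show why, or how the change would behave on any further core.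

Each core is seen here with only these two fluorophenyl groups. As far as these compounds go, it remains open whether a phenyl group without fluorine, or a chlorophenyl group, on that aromatic nitrogen would behave alike on both cores.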